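Chloro for fluoro on the benzylic aryl ring

The compounds below may be only part of what the source reports. "The series", "measured", "known", "first", "only" and "open" are said of these compounds alone.

Compound 1 `COc1cc(OC)c(/C=C/S(=O)(=O)Cc2ccc(F)c(N)c2)c(OC)c1` and compound 2 `COc1cc(OC)c(/C=C/S(=O)(=O)Cc2ccc(Cl)c(N)c2)c(OC)c1` share one core; compound 3 `COc1cc(OC)c(/C=C/S(=O)(=O)Cc2ccc(OC)c(NC(C(=O)O)c3ccc(F)cc3)c2)c(OC)c1` and compound 4 `COc1cc(OC)c(/C=C/S(=O)(=O)Cc2ccc(OC)c(NC(C(=O)O)c3ccc(Cl)cc3)c2)c(OC)c1` share another, and the difference between the two cores is not broken down here. In a functional assay on K562 cells (Homo sapiens) for cytotoxicity, read by trypan blue exclusion, with a stated time of 96 h (on this read-out higher numbers stand for weaker inhibition and lower numbers for stronger inhibition), compound 1 gives 2500 nM, while compound 2 gives 10 nM; the step of a 250-fold lower number from compound 1 to compound 2 (2.40 log units; beyond the scatter) follows the change (chloro in place of fluoro on an aromatic carbon). In this assay compound 3 gives 80 nM.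

Compound 4 carries the same kind of change, (chloro in place of fluoro on an aromatic carbon), but its surroundings differ: in the first pair the place is also ortho to an amino group (1 heavy atom), whereas in the second pair the place is only para to a large group, and the change sits out on the carboxy(4-fluorophenyl)methyl arm rather than on the ring that bears the sulfonyl. For the measured compounds named here, the earlier step rests on a single pair, so its size is not taken over as such; a smaller gain is expected, a 2.7-fold lower number from compound 3 to compound 4 (0.43 log units; beyond the scatter), because the direction of a 250-fold lower number from compound 1 to compound 2 (2.40 log units; beyond the scatter) is the only guide. Compound 4 is therefore estimated at 30 nM, between 8 nM and 150 nM.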

Compound 4, half-maximal inhibitory concentration: 250 nM
Compound 4: middle estimate off by 8.3-fold (0.92 log units), on the low side; measured number above the stated range.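

In this assay, the step on the carboxy(4-fluorophenyl)methyl arm is a 3.1-fold higher number from compound 3 to compound 4 (0.49 log units; beyond the scatter), so chloro in place of fluoro runs in the opposite direction to the step on the core of compound 1. Set side by side, the two steps show that neither the size nor the direction of this change carried over from one core to the other: the same change on two cores in this assay, a 250-fold lower number (2.40 log units; beyond the scatter) from compound 1 to compound 2 and a 3.1-fold higher number (0.49 log units; beyond the scatter) from compound 3 to compound 4, 780-fold (2.89 log units) apart, beyond the scatter of two such steps

This does not show what separates the two results: the pairs differ both in their core and in where the change sits, and each step rests on a single pair.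

From the compounds shown here alone, it remains open whether the opposite direction goes with the carboxy(4-chlorophenyl)methyl arm itself or with the rest of the core. Going by these compounds, it is also open how a bromo or methyl group would compare in the place of the halogen on this arm, and whether the step between compound 3 and compound 4 would persist with a methyl ester in place of the carboxylic acid.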